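From 2-chlorophenyl to phenyl: a small step expected

The compounds below may be only part of what the source reports. "The series", "measured", "known", "first", "only" and "open" are said of these compounds alone.

In a functional assay on HCT-116 cells (Homo sapiens) for inhibition, read by CCK-8 assay, with a stated time of 72 h (on this read-out lower numbers stand for stronger inhibition and higher numbers for weaker inhibition), compound 1 `Nc1ccccc1NC(=O)c1ccc(CNC(=O)c2n[nH]cc2NC(=O)c2c(F)cccc2Cl)cc1` gives 700 nM and compound 2 `Nc1ccccc1NC(=O)c1ccc(CNC(=O)c2n[nH]cc2NC(=O)c2ccccc2Cl)cc1` gives 900 nM. Going by the values given here, these two numbers lie within the scatter of each other, so compound 2 stands level with the only other measured compound. Compound 3 `Nc1ccccc1NC(=O)c1ccc(CNC(=O)c2n[nH]cc2NC(=O)c2ccccc2)cc1` has not yet been measured. It differs from compound 2 as follows: hydrogen in place of chloro on an aromatic carbon. In other words, hydrogen stands in place of chloro on an aromatic carbon, ortho to a large group, turning 2-chlorophenyl into phenyl. Among the compounds with values here, only one measured step bears on this change, and it is an indirect guide: a 1.3-fold higher number from compound 1 to compound 2 (0.11 log units; within the scatter), where hydrogen replaced fluoro rather than chloro. The data hold no measured removal of chloro itself. With that single small step as the basis, only a slight move towards a higher number in this assay is expected, with nothing clearly beyond the scatter. The expected step is a 1.3-fold higher number from compound 2 to compound 3 (0.12 log units; within the scatter). For compound 3 the estimate is 1200 nM, with an expected range from 550 nM to 2800 nM.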

Compound 3, half-maximal inhibitory concentration: 1660 nM
Compound 3: middle estimate off by 1.4-fold (0.14 log units), on the low side, and the stated range covers the measured number.
By their numbers in this assay, from the lowest: compounds 1, 2 and 3 (each within the scatter of the next, the first and the last beyond it).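

In this assay, hydrogen in place of chloro alone, on the aromatic carbon ortho to a large group, gives a 1.8-fold higher number from compound 2 to compound 3 (0.27 log units; within the scatter) and so does not by itself carry the number past the scatter. Going by these compounds alone, with both halogens gone, the change from 2-chloro-6-fluorophenyl to phenyl gives a 2.4-fold higher number from compound 1 to compound 3 (0.38 log units; beyond the scatter) as the only step among the three compounds to pass the scatter, though only modestly, and this is something the earlier pair could not show. Nothing available explains this step.

The compounds shown leave open whether the fluoro alone, with the chloro gone, would stand closer to compound 1 or to compound 3. They also leave open how a methyl, a methoxy or an amine on the same aromatic carbon would compare with chloro and with hydrogen.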